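The compounds below may be only part of what the source reports. "The series", "measured", "known", "first", "only" and "open" are said of these compounds alone.

Compound 1 `CCCCc1oc2ccc(/N=C/c3ccc(F)cc3)cc2c1C(=O)c1ccc(OC)cc1`: 100 ug/mL
Compound 2 `CCCCc1oc2ccc(/N=C/c3ccc(CC)cc3)cc2c1C(=O)c1ccc(OC)cc1`: 3.69 ug/mL

Going by the values given here, in a functional assay, with a stated time of 30 min (on this read-out lower numbers stand for stronger inhibition and higher numbers for weaker inhibition), compound 1, at 100 ug/mL, has the higher of the two numbers measured so far, which makes it the weaker inhibitor of the pair. Compound 3 `CCCCc1oc2ccc(/N=C/c3ccc(OCC)c(OC)c3)cc2c1C(=O)c1ccc(OC)cc1` has not yet been measured. It keeps the core of compound 1 and changes one group: 4-ethoxy-3-methoxyphenyl in place of 4-fluorophenyl on a carbon with a double bond to nitrogen. In words, 4-ethoxy-3-methoxyphenyl stands in place of 4-fluorophenyl on a carbon with a double bond to nitrogen.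

Among the compounds with values here, only one measured step bears on this change: a 27-fold lower number from compound 1 to compound 2 (1.43 log units; beyond the scatter). That step is large and beyond the scatter, and it also removes the fluoro. It does not show what an ethoxy or a methoxy group does, and a single step cannot establish a trend. A sizeable move towards a lower number in this assay is therefore expected, though with wide uncertainty, and the expectation rests on compound 2 at 3.69 ug/mL. The estimated change is a 10-fold lower number from compound 1 to compound 3 (1.00 log units; beyond the scatter). For compound 3 the expected value is 10 ug/mL, with an estimated range of 2 ug/mL to 60 ug/mL.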

Compound 3, half-maximal inhibitory concentration: 14.8 ug/mL
Compound 3: middle estimate off by 1.5-fold (0.17 log units), on the low side, within the range that was stated.
By their numbers in this assay, from the lowest: compound 2; then compound 3; then compound 1.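

In this assay, the change a 6.8-fold lower number from compound 1 to compound 3 (0.83 log units; beyond the scatter) shows that 4-fluorophenyl on a carbon with a double bond to nitrogen can be replaced by a second group with a move to a lower number, so this gain no longer rests on the ethyl of compound 2 alone. The replacements are not equivalent, however: the change a 4.0-fold higher number from compound 2 to compound 3 (0.60 log units; beyond the scatter) places 4-ethoxy-3-methoxyphenyl behind 4-ethylphenyl, and with all three compounds separated beyond the scatter, this position distinguishes among the groups placed on it. Nothing available explains why these groups rank as they do.

The compounds shown leave open how much of the difference belongs to the ethoxy and how much to the methoxy, since the two enter together in compound 3 and neither appears alone. They also leave open what a propyl chain or an amine on the aromatic ring, in place of the ethyl of compound 2, would give in this assay and whether either would match or improve on that compound.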